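Series notes: substituent on the six-membered ring of the shared core

The source may hold more compounds than are shown below. What is called first, only, known or untested is meant among the compounds shown, and "the series" means these compounds.

Measured so far:
compound 1, `Cc1nc(N)c2nc(O)n(Cc3ccccc3)c2n1`: 1 uM
compound 2, `CCNc1nc(N)c2nc(O)n(Cc3ccccc3)c2n1`: 1 uM
compound 3, `CCCNc1nc(N)c2nc(O)n(Cc3ccccc3)c2n1`: 0.1 uM

In a functional assay (spleen, spleen) for activation, with Mus musculus as the target (on this read-out higher numbers stand for an effect only at larger amounts of compound and lower numbers for an effect already at smaller amounts), compound 1 gives 1 uM, level with compound 2 and together the highest number of the three; compound 3 is the one furthest from it, with the lowest number.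

Compound 4, `CCCC[S+]([O-])c1nc(N)c2nc(O)n(Cc3ccccc3)c2n1`, is not yet measured. Against compound 1 the change is a group of 6 heavy atoms (4 carbon, 1 oxygen, 1 sulfur; no ring) in place of one carbon atom, on an aromatic carbon.

Two measured steps start from compound 1 at the same aromatic carbon: no change at the digits printed from compound 1 to compound 2 (within the scatter), and a 10-fold lower number from compound 1 to compound 3 (1.00 log units; beyond the scatter). The longer chain in compound 3 goes with the lower number, and the step of a 10-fold lower number from compound 2 to compound 3 (1.00 log units; beyond the scatter) points the same way. The entering group of compound 4 is larger still, though it carries a sulfur and an oxygen rather than a nitrogen, so the measured steps are only a loose guide. A modest lowering of the number is therefore expected, with wide uncertainty: a 3.3-fold lower number from compound 1 to compound 4 (0.52 log units; beyond the scatter). For compound 4 in this assay the estimate is 0.3 uM, ranging from 0.05 uM to 2 uM.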

Compound 4, minimum effective concentration: 0.01 uM
For compound 4 the middle estimate is 30-fold (1.48 log units) above the measured one; measured number outside the range, below it.
By their numbers in this assay, from the lowest: compound 4; then compound 3; then compounds 1 and 2 (each within the scatter of the next).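

In this assay the group of 6 heavy atoms carrying sulfur and oxygen, on the aromatic carbon between two ring nitrogen atoms, gives a 100-fold lower number from compound 1 to compound 4 (2.00 log units; beyond the scatter) and a 100-fold lower number from compound 2 to compound 4 (2.00 log units; beyond the scatter) so this position spans a much wider range than the earlier chain steps showed. The same change also gives a 10-fold lower number from compound 3 to compound 4 (1.00 log units; beyond the scatter) so among the compounds shown, a nitrogen attached to this carbon is not required for the lowest number. No measurement shown accounts for this result.

The compounds shown leave open whether the lower number follows from the 4 carbon atoms of the chain or from the sulfur and oxygen link. A butylamino group and a butylthio group at this carbon would separate those two contributions.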